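A few compounds are considered here, and "the series" means these few. Any claim that something is new, unique, unknown or untested is made for them only; others in the source may bear on it.

Measured compounds:

Compound 1 `CNC(=O)[C@@]12C[C@@H]1[C@@H](n1cnc3c(NC)nc(C#Cc4cccnn4)nc31)[C@H](O)[C@@H]2O`, in an assay on CHO cells for displacement of a labelled ligand from adenosine receptor A1 (Homo sapiens), read by scintillation counting, with a stated time of 60 min, tested at 10 uM (on this read-out lower numbers stand for less inhibition and higher numbers for more inhibition at the one concentration tested (going by the name of the read-out)), compound 1 gives 11%.
Compound 2 `CNC(=O)[C@@]12C[C@@H]1[C@@H](n1cnc3c(NC)nc(C#Cc4cc5ccccc5o4)nc31)[C@H](O)[C@@H]2O`, in this assay compound 2 gives 13%.

Among the compounds with values here, compound 2 has the higher of the two numbers seen in this assay, but its only neighbour is compound 1, and the step of a number 2 percentage points higher from compound 1 to compound 2 (within the scatter) lies within the scatter, so the two cannot be told apart. That step exchanged pyridazin-3-yl for 1-benzofuran-2-yl on a triple-bonded carbon and left the read-out essentially unchanged.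

Compound 3 `CNC(=O)[C@@]12C[C@@H]1[C@@H](n1cnc3c(NC)nc(C#Cc4nccs4)nc31)[C@H](O)[C@@H]2O` differs from compound 2 at the same place: 1,3-thiazol-2-yl in place of 1-benzofuran-2-yl on a triple-bonded carbon. Within the data shown here, the one measured step that bears on this change is the one from compound 1 to compound 2, an exchange of the group on the triple-bonded carbon, and it stayed within the scatter. Nothing seen so far suggests that swapping this group moves the read-out in this assay, so for compound 3 no step beyond the scatter is expected in either direction, the expected step being a number 1 percentage points lower from compound 2 to compound 3 (within the scatter). Compound 3 is therefore estimated to give about 12% in this assay, most likely between 2% and 25%.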

Compound 3, a percentage reported as inhibition, at one concentration (the size of the read-out at that concentration, not a potency): 31%
The estimate for compound 3 lay 19 percentage points below the measured number, outside the stated range (above it).
By their numbers in this assay, from the lowest: compounds 1 and 2 (each within the scatter of the next); then compound 3.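

In this assay, within the data shown here, the group on the triple-bonded carbon turns out to matter, which the first pair of compounds gave no sign of: 1,3-thiazol-2-yl in place of 1-benzofuran-2-yl gives a number 18 percentage points higher from compound 2 to compound 3 (beyond the scatter) and 1,3-thiazol-2-yl in place of pyridazin-3-yl gives a number 20 percentage points higher from compound 1 to compound 3 (beyond the scatter). So this position can move the read-out, and two different groups that sat within the scatter of each other both stand apart from 1,3-thiazol-2-yl, although the shift is modest and, at one concentration, says nothing about potency. No measurement is available to explain why this group differs from the other two.

Among these compounds, with only one compound carrying 1,3-thiazol-2-yl, the data cannot separate the roles of its sulfur, its ring nitrogen and the absence of a fused six-membered ring. Groups such as 1,3-oxazol-2-yl, thiophen-2-yl or 1,3-benzothiazol-2-yl on the same triple-bonded carbon would pull these features apart, and whether the rise holds for any group beyond this single example remains open.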